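This account rests on a few compounds, and the source may have more. Where it says the series, first, only, none or still open, it means among the compounds named here.

Within the data shown here, compound 2 `CS(=O)(=O)c1ccc(F)c(C#Cc2cc(Cl)ccc2OCC(=O)O)c1` is one of three compounds measured in an ADME assay on a cell-free system (plasma, Rattus norvegicus); on this read-out higher numbers stand for a larger free fraction and lower numbers for a smaller free fraction. Compound 2 gives 0.011, compound 1 `COCCN(C)S(=O)(=O)c1ccc(C)c(C#Cc2cc(Cl)ccc2OCC(=O)O)c1` gives 0.007, and these two numbers lie within the usual scatter of each other. Compound 3 `Cc1ccc(S(=O)(=O)NC(C)C)cc1C#Cc1cc(Cl)ccc1OCC(=O)O` gives 0.004, and its gap from compound 2 lies beyond the scatter. Compound 4 `CCCS(=O)(=O)c1ccc(F)c(C#Cc2cc(Cl)ccc2OCC(=O)O)c1` differs from compound 2 by ethyl in place of hydrogen on a saturated chain carbon bound to a sulfonyl sulfur. Among the measured compounds shown here, the only measured step made at the sulfonyl group is a 1.8-fold lower number from compound 1 to compound 3 (0.24 log units; within the scatter), and it sits on the nitrogen rather than on a chain carbon. With that alone to go on, no step beyond the scatter is expected in this assay when moving from compound 2 to compound 4. Compound 4 is therefore estimated at 0.009, with a range from 0.004 to 0.02, which corresponds to an expected step of a 1.2-fold lower number from compound 2 to compound 4 (0.09 log units; within the scatter).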

Compound 4, unbound fraction: 0.004
For compound 4 the middle estimate is 2.3-fold (0.35 log units) above the measured one; the range from low to high includes it.
By their numbers in this assay, from the lowest: compounds 3, 4, 1 and 2 (each within the scatter of the next, the first and the last beyond it).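

In this assay, among these compounds, the change gives a 2.8-fold lower number from compound 2 to compound 4 (0.44 log units; beyond the scatter), the first measured step on a saturated chain carbon bound to a sulfonyl sulfur. Among the compounds shown here, the only earlier step at the sulfonyl group, made on its nitrogen, stayed within the scatter, whereas this one lies beyond it, so ethyl in place of hydrogen at this carbon does shift the free fraction. Nothing available explains this shift. On these data alone, it remains open whether ethylsulfonyl or butylsulfonyl would follow the same direction, and how a propyl chain ending in an amine or a carboxylic acid would compare.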